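The source may report more compounds than this note shows. Statements on the series, on what has been measured and on what is new or still open speak of the compounds shown alone.

Measured in a functional assay on A549 cells (Homo sapiens) for antiproliferative activity, read by MTT assay, with a stated time of 48 h; a higher number here means a weaker inhibitor, a lower number a stronger inhibitor:
- compound 1 `COc1ccc(N(C)c2ccnc(Cl)n2)cc1[N+](=O)[O-]`: 3780 nM
- compound 2 `COc1ccc(N(C)c2ccnc(Cl)n2)cc1OCCCCCBr`: 9720 nM

Of the two measured compounds, compound 2 has the higher number, so it is the weaker inhibitor in this assay. For the measured compounds named here, the one measured step, a 2.6-fold higher number from compound 1 to compound 2 (0.41 log units; beyond the scatter), was modest and put (5-bromopentyl)oxy in place of nitro on an aromatic carbon.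

Compound 3 `COc1ccc(N(C)c2ccnc(Cl)n2)cc1OCCC[Se]C#N` has not yet been measured. It differs from compound 2 by a group of 3 heavy atoms (1 carbon, 1 nitrogen, 1 selenium; no ring) in place of a group of 3 heavy atoms (2 carbon, 1 bromine; no ring), on a saturated chain carbon, three bonds along the chain from an oxygen on an aromatic ring. Going by the values given here, no measured step touches this end of the chain or this entering group, so the single step available serves only as a rough guide to size and says nothing firm about direction. In compound 1 the shared core gives 3780 nM, which leaves room for a lower number than in compound 2. A lower number is therefore the expected direction, on thin evidence, with a step of modest size or somewhat larger.

The expected step is a 3.9-fold lower number from compound 2 to compound 3 (0.59 log units; beyond the scatter). The estimate for compound 3 is 2500 nM, with an expected range of 300 nM to 10000 nM.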

Compound 3, half-maximal inhibitory concentration: 3710 nM
For compound 3 the middle estimate is 1.5-fold (0.17 log units) below the measured one; low and high end bracket the measured number.
By their numbers in this assay, from the lowest: compounds 3 and 1 (each within the scatter of the next); then compound 2.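

Notes on the chain end: in this assay, replacing 2-bromoethyl with a selenocyanate group gives a 2.6-fold lower number from compound 2 to compound 3 (0.42 log units; beyond the scatter), so changes at this end of the chain can move the number beyond the scatter, although the step alters the chain length and the end group together. Against the nitro compound, the whole chain-bearing substituent on the aromatic carbon gives a 1.0-fold lower number from compound 1 to compound 3 (0.01 log units; within the scatter), so an ether chain at this place is compatible with a number level with that of compound 1 when it ends in selenocyanate, while the bromo-ended chain of compound 2 stays apart from both. No supporting data bear on why the chain end matters, and the result therefore stands as an observation only.

The contributions of chain length and end group remain unseparated: a 3-bromopropyl ether, or a selenocyanate on a pentyl chain, would divide them. As far as these compounds go, whether selenium itself matters also stays open, and a thiocyanate or a plain nitrile at the same chain end would test that, as would an amine for an end group without a triple bond.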